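Swapping a Phenyl for a Propyl on a Shared Core

A few compounds are considered here, and "the series" means these few. Any claim that something is new, unique, unknown or untested is made for them only; others in the source may bear on it.

Of the compounds shown here, three with a shared core have been measured in a functional assay on DU-145 cells (Homo sapiens) for inhibition, read by MTT assay, with a stated time of 2 days; on this read-out lower numbers stand for stronger inhibition of growth and higher numbers for weaker inhibition of growth. Compound 1 `O=C(Nn1c(-c2cccc([N+](=O)[O-])c2)nc2c(-c3ccc(Cl)cc3)n[nH]c2c1=O)c1ccccc1` gives 17100 nM. Compound 2 `COc1cccc(-c2nc3c(-c4ccc(Cl)cc4)n[nH]c3c(=O)n2NC(=O)c2ccccc2)c1` gives 17900 nM, and compound 3 `O=C(Nn1c(-c2ccccc2)nc2c(-c3ccc(Cl)cc3)n[nH]c2c1=O)c1ccccc1` gives 20100 nM. The steps of a 1.0-fold higher number from compound 1 to compound 2 (0.02 log units; within the scatter), a 1.2-fold higher number from compound 1 to compound 3 (0.07 log units; within the scatter) and a 1.1-fold higher number from compound 2 to compound 3 (0.05 log units; within the scatter) all lie within the scatter, so compound 3 cannot be told apart from the other two on these numbers.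

Compound 4 `CCCc1nc2c(-c3ccc(Cl)cc3)n[nH]c2c(=O)n1NC(=O)c1ccccc1` differs from compound 3 in one place: propyl in place of phenyl on an aromatic carbon. The measured steps only swap groups on that phenyl, never the phenyl itself, so none of them bears on this change. Compound 4 is expected to give about 20000 nM, between 7000 nM and 60000 nM. That estimate means a step of a 1.0-fold lower number from compound 3 to compound 4 (0.00 log units; within the scatter), with no direction expected beyond the scatter.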

Compound 4, concentration for 50% growth inhibition: 29200 nM
Estimate against measurement, compound 4: 1.5-fold (0.16 log units) below; the measured number falls inside the stated range.
By their numbers in this assay, from the lowest: compounds 1, 2, 3 and 4 (each within the scatter of the next).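

In this assay, among the compounds shown here, a ring at this position gives way for the first time to an open chain, and the steps of a 1.5-fold higher number from compound 3 to compound 4 (0.16 log units; within the scatter) and a 1.6-fold higher number from compound 2 to compound 4 (0.21 log units; within the scatter) and a 1.7-fold higher number from compound 1 to compound 4 (0.23 log units; within the scatter) all lie within the scatter. On these compounds, then, an aromatic ring at this position is not needed to keep the number inside the scatter of the phenyl compounds. Nothing measured here explains this result.

Still open, as far as these compounds go, is whether a longer chain such as hexyl, an amine or a carboxylic acid at this position would move the number beyond the scatter.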